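The source may hold more compounds than are shown below. What is called first, only, known or untested is meant among the compounds shown, and "the series" means these compounds.

Measured compounds:
Compound 1 `CC1(C)CC2CC(C)(CN2C(=O)c2sc(-c3ccc(S(C)(=O)=O)c([N+](=O)[O-])c3)nc2C(F)(F)F)C1` — in a functional assay for antagonist activity at thyroid hormone receptor alpha (Homo sapiens), read by fluorescence polarization (on this read-out lower numbers stand for stronger inhibition and higher numbers for weaker inhibition), compound 1 gives 430 nM.
Compound 2 `Cc1nc(-c2ccc(S(C)(=O)=O)c([N+](=O)[O-])c2)sc1C(=O)N1CC2(C)CC1CC(C)(C)C2` — in this assay compound 2 gives 3500 nM.

Among the measured compounds shown here, compound 1 holds the lowest of the two numbers; its only neighbour is compound 2, and the step of an 8.1-fold higher number from compound 1 to compound 2 (0.91 log units; beyond the scatter) comes from methyl in place of trifluoromethyl on an aromatic carbon. Compound 3 `CS(=O)(=O)c1ccc(-c2nc(C(F)(F)F)c(C(=O)N3CCCCC3)s2)cc1[N+](=O)[O-]` keeps the trifluoromethyl and the rest of compound 1 but alters the amide portion: a group of 6 heavy atoms (5 carbon, 1 nitrogen; one six-membered non-aromatic ring with 1 hetero atom) in place of a group of 11 heavy atoms (10 carbon, 1 nitrogen; one five-membered non-aromatic ring with 1 hetero atom, one six-membered non-aromatic ring of carbon only), on a carbonyl carbon. For the measured compounds named here, no measured step touches this part of the molecule; the single step on record, from compound 1 to compound 2, concerns a substituent on the aromatic ring and offers no guidance on a change at the carbonyl carbon. The expectation for compound 3 therefore rests on compound 1 alone and carries wide uncertainty. A modest move toward a higher number in this assay is expected, a 3.5-fold higher number from compound 1 to compound 3 (0.54 log units; beyond the scatter). Compound 3 is estimated at 1500 nM, within a range from 300 nM to 8000 nM.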

Compound 3, half-maximal inhibitory concentration: 100 nM
The estimate for compound 3 lay 15-fold (1.18 log units) above the measured number, outside the stated range (below it).
By their numbers in this assay, from the lowest: compound 3; then compound 1; then compound 2.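

The earlier compounds shown here said nothing about the amide portion, and here it proves to be a place where this assay responds: with piperidin-1-yl on the carbonyl carbon in place of the group of 11 heavy atoms, the result is a 4.3-fold lower number from compound 1 to compound 3 (0.63 log units; beyond the scatter). With the trifluoromethyl kept, the second ring and the extra carbons of compound 1 are therefore not required for a low number in this assay, and the smaller group gives the lower one. Nothing measured here accounts for this difference.

From the compounds shown here alone, it remains open whether the methyl for trifluoromethyl change would cost as much with piperidin-1-yl on the carbonyl carbon as it does with the larger group. The compounds shown also leave open how other amines in that place, such as pyrrolidin-1-yl or morpholin-4-yl, would compare with piperidin-1-yl.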